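The source may report more compounds than this note shows. Statements on the series, on what has been measured and on what is new or still open speak of the compounds shown alone.

Measured compounds:
compound 1 `c1ccc(-c2cnccn2)c(OCC2=NCCN2)c1` — in a functional assay with Alpha-1A adrenergic receptor (Homo sapiens) as the target, read by calcium flux (a lower number here means a smaller maximal response, a higher number a larger maximal response), compound 1 gives 97%
compound 2 `c1ccc(-c2ccns2)c(OCC2=NCCN2)c1` — in this assay compound 2 gives 99%

Within the data shown here, compound 2 stands with compound 1 inside the scatter of this assay: the only measured step, a number 2 percentage points higher from compound 1 to compound 2 (within the scatter), does not rise above the noise, so the two are read as equal in maximal response. Both reach a near-full response against the reference.

Compound 3 `Cc1csc(-c2ccccc2OCC2=NCCN2)n1` is not yet measured. It differs from compound 2 by 4-methyl-1,3-thiazol-2-yl in place of 1,2-thiazol-5-yl on an aromatic carbon.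

Among the measured compounds shown here, the single measured step bears on this change in that it also exchanges one five-membered aromatic ring with two hetero atoms for another at the same aromatic carbon, and that step, a number 2 percentage points higher from compound 1 to compound 2 (within the scatter), stayed within the scatter. Nothing measured distinguishes one such ring from another here. The expectation for compound 3 in this assay is therefore no step beyond the scatter, a number 4 percentage points lower from compound 2 to compound 3 (within the scatter), with the added methyl group untested in the series. Compound 3 is estimated at 95%, in the range 80% to 105%.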

Compound 3, largest response reached (reported as maximum), in percent of the reference or control that the assay uses: 104%
Estimate against measurement, compound 3: 9 percentage points below; the measured number falls inside the stated range.
By their numbers in this assay, from the lowest: compounds 1, 2 and 3 (each within the scatter of the next).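

In this assay, 4-methyl-1,3-thiazol-2-yl in place of 1,2-thiazol-5-yl on the aromatic carbon gives (  a number 5 percentage points higher from compound 2 to compound 3 (within the scatter)  ), and the same group in place of pyrazin-2-yl gives (  a number 7 percentage points higher from compound 1 to compound 3 (within the scatter)  ). Among these compounds, this position, ortho to a group of 7 heavy atoms, therefore now holds a ring bearing a methyl group as well as two unsubstituted rings, and the series shows no step beyond the scatter: the added methyl group and the change of ring both leave the maximal response of compounds 1, 2 and 3 indistinguishable, and no compound among the three goes against this reading. Nothing available explains this flat response or says what the ring contributes to it.

The compounds shown leave open whether the maximal response stays flat when this aromatic carbon carries something other than a heteroaromatic ring, such as a primary amine or a carboxylic acid. Among the compounds shown here, they also leave open whether a longer chain, such as n-butyl, in place of the methyl group on the thiazole ring would produce the first step beyond the scatter.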